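The source may report more compounds than this note shows. Statements on the series, on what has been measured and on what is new or still open speak of the compounds shown alone.

Notes on the series in an ADME assay on microsomes from liver (Homo sapiens) for metabolic stability, read by LC-MS, with NADPH named in the record, with a stated time of 60 min, tested at 1 uM, in the absence of a further agent; on this read-out lower numbers stand for a less stable compound and higher numbers for a more stable compound. Compound 1 `CC(=O)N[C@@H]1CCN(c2cc(C)nn3c(-c4ccc(C(F)(F)F)cc4)c(C)nc23)C1` gives > 95%, which is a limit and not a number. Compound 2 `CC(=O)N[C@@H]1CCN(c2cc(C)nn3c(-c4cccs4)c(C)nc23)C1` gives > 95%, also a limit and not a number. Both values shown therefore sit at one limit: the limit of > 95% in this assay, at which 2 of the 2 values shown sit. Compound 3 `CC(=O)N[C@@H]1CCN(c2cc(C)nn3c(-c4ccco4)c(C)nc23)C1` has furan-2-yl in place of thiophen-2-yl on an aromatic carbon, next to the ring nitrogen: furan-2-yl in place of thiophen-2-yl on an aromatic carbon. Within the data shown here, the only measured step that bears on this change is a step that the two limits leave unreadable from compound 1 to compound 2, also a replacement of the group at this place, and it has no readable size. It offers no size to carry over, so no step beyond the scatter is expected in this assay, in either direction. The estimated step is a number at least 1 percentage points lower from compound 2 to compound 3 (that floor lies within the scatter). For compound 3 the expected value is 94%, with an estimated range from 80% to 100%.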

Compound 3, percent of the compound remaining: > 95%
Compound 3 ended at the assay's limit; the forecaster's own chance of this, stated with the estimate: 50%; middle value at least 1 percentage points away from the limit.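

Among these compounds, compound 3 gives > 95% as a limit and not a number, so no step among compound 1, compound 2 and compound 3 can be read. The compounds shown leave open whether thiophen-2-yl, furan-2-yl and 4-(trifluoromethyl)phenyl differ at all in stability, since all values rest on one limit: the limit of > 95% in this assay, at which 3 of the 3 values shown sit.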